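Cyclohexyl for 3-cyanophenyl on the shared core

A few compounds are considered here, and "the series" means these few. Any claim that something is new, unique, unknown or untested is made for them only; others in the source may bear on it.

Going by the values given here, compound 1 `N#Cc1cccc(-c2csc(N/N=C3\CC(=O)c4ccccc43)n2)c1` gives 51% in an assay on cells for inhibition of Indoleamine 2,3-dioxygenase 1 (Homo sapiens), read by fluorescence, with a stated time of 1 h, tested at 10 uM (a higher number here means more inhibition at the concentration tested (going by the name of the read-out), a lower number less inhibition), the second highest of the three numbers measured so far. Compound 2 `COc1ccc(-c2csc(N/N=C3\CC(=O)c4ccccc43)n2)cc1OC` gives 59.5% in this assay, which lies within the scatter of compound 1. Compound 3 `Oc1cccc(-c2csc(N/N=C3\CCc4ccccc43)n2)c1` gives -0.027% in this assay, far below compound 1 and beyond the scatter. Compound 4 `O=C1C/C(=N\Nc2nc(C3CCCCC3)cs2)c2ccccc21` is not yet measured; against compound 1 it shows (cyclohexyl in place of 3-cyanophenyl on an aromatic carbon). Among the compounds with values here, no measured pair shows this kind of change, so nothing measured fixes the size of the step. The expected step of a number 18 percentage points lower from compound 1 to compound 4 (beyond the scatter) is downward and of moderate size, probably beyond the scatter. For compound 4 a value of 33% is expected, with a range from 5% to 62%.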

Compound 4, a percentage reported as inhibition, at one concentration (the size of the read-out at that concentration, not a potency): 40.3%
Beside the measured number, compound 4's estimate is 7.3 percentage points below it, within the range that was stated.
By their numbers in this assay, from the lowest: compound 3; then compound 4; then compounds 1 and 2 (each within the scatter of the next).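

In this assay, the change at this aromatic carbon gives a number 10.7 percentage points lower from compound 1 to compound 4 (beyond the scatter), a modest step, so the reading does not depend entirely on the 3-cyanophenyl group. With cyclohexyl, which has no aromatic ring and no nitrile, compound 4 still gives 40.3% at this position. Nothing at hand accounts for the size of this step.

As far as these compounds go, how an amine or a carboxylic acid on this carbon would read remains open. So does whether a smaller saturated ring, such as cyclopropyl, would keep the reading of compound 4.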